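From 3-chlorophenyl to 4-chlorophenyl on a sulfonyl sulfur

The source may report more compounds than this note shows. Statements on the series, on what has been measured and on what is new or still open speak of the compounds shown alone.

- Compound 1 (`Cc1ccc(S(=O)(=O)NC(=N)N2CCN(c3cc4c(cc3F)c(=O)c(C(=O)O)cn4C3CC3)CC2)cc1`) gives 32 nM
- Compound 2 (`N=C(NS(=O)(=O)c1cccc(Cl)c1)N1CCN(c2cc3c(cc2F)c(=O)c(C(=O)O)cn3C2CC2)CC1`) gives 32 nM

In a functional assay on HeLa cells (Homo sapiens) for antiproliferative activity, read by MTT assay, with a stated time of 72 h (a higher number here means a weaker inhibitor, a lower number a stronger inhibitor), compound 2 gives 32 nM and stands level with compound 1. Compound 3 (`N=C(NS(=O)(=O)c1ccc(Cl)cc1)N1CCN(c2cc3c(cc2F)c(=O)c(C(=O)O)cn3C2CC2)CC1`) differs from compound 2 by a single change (4-chlorophenyl in place of 3-chlorophenyl on a sulfonyl sulfur): 4-chlorophenyl in place of 3-chlorophenyl on a sulfonyl sulfur. Within the data shown here, only one measured step bears on this, namely 3-chlorophenyl in place of 4-methylphenyl at that same place. Among the measured compounds shown here, it showed no change at the digits printed from compound 1 to compound 2 (within the scatter) and is a single case, and no measured compound yet carries 4-chlorophenyl. With only no change at the digits printed from compound 1 to compound 2 (within the scatter) as a guide, no shift beyond the scatter is expected in this assay for the new compound. The expected step is no change at the digits printed from compound 2 to compound 3 (within the scatter) on this estimate. The estimate for compound 3 is 32 nM and its expected range runs from 12 nM to 90 nM for repeated measurements.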

Compound 3, half-maximal inhibitory concentration: 32 nM
Beside the measured number, compound 3's estimate shows no gap at the digits printed; the range from low to high includes it.
By their numbers in this assay, from the lowest: compounds 1, 2 and 3 (each within the scatter of the next).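

In this assay, 4-chlorophenyl in place of 3-chlorophenyl on the sulfonyl sulfur gives no change at the digits printed from compound 2 to compound 3 (within the scatter), so among these compounds the two placements of the same chlorine cannot be told apart. Chloro in place of methyl on an aromatic carbon, a swap of one small group for another with the rest of the molecule unchanged, likewise gives no change at the digits printed from compound 1 to compound 3 (within the scatter), so all three aromatic groups on the sulfonyl sulfur sit level in this assay. No measurement shown offers an explanation for this flat result.

All three compounds carry one small group on that aromatic ring, so these values say little about how far the ring tolerates change. An amine, a carboxylic acid or a longer chain such as butyl on the ring, or plain phenyl with no added group, remains an open case.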